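A few compounds are considered here, and "the series" means these few. Any claim that something is new, unique, unknown or untested is made for them only; others in the source may bear on it.

Measured in a functional assay on MCF7 cells (Homo sapiens) for antiproliferative activity, read by MTT assay, with a stated time of 72 h (a higher number here means a weaker inhibitor, a lower number a stronger inhibitor), as follows:
- compound 1 `NC(=S)N/N=C/c1ccccc1O` gives >= 5000 nM as a limit
- compound 2 `COc1cccc(/C=N/NC(=S)Nc2ccccc2)c1O` gives 3000 nM as a number
- compound 3 `Oc1ccccc1/C=N/NC(=S)Nc1ccccc1` gives 4000 nM as a number

Compound 2 has one numeric neighbour, and the step to it is a 1.3-fold higher number from compound 2 to compound 3 (0.12 log units; within the scatter) with no order between the two. For compound 1 the reading is the limit of >= 5000 nM in this assay, at which 1 of the 3 values shown sits, and so a limit rather than a number.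

Compound 4 `COc1cccc(/C=N/NC(N)=S)c1O` follows from compound 2 by hydrogen in place of phenyl on an amide-type nitrogen that is, hydrogen in place of phenyl on an amide-type nitrogen. The same change, read in reverse, joins compound 3 to compound 1. Within the data shown here, that pair gives the only measured step of this kind, an at least 1.2-fold lower number from compound 1 to compound 3 (0.09 log units; that floor lies within the scatter) and it is bounded on one side only. The methoxy difference between compound 2 and compound 3 stayed within the scatter, so that pair is taken as a usable guide. The expected step is a 1.7-fold higher number from compound 2 to compound 4 (0.22 log units; within the scatter) in the direction of a higher number and not firmly beyond the scatter. For compound 4 the estimated value is 5000 nM with an expected range from 2500 nM to 12000 nM in this read-out.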

Compound 4, half-maximal inhibitory concentration: 300 nM
Beside the measured number, compound 4's estimate is 17-fold (1.22 log units) above it; measured number below the stated range.
By their numbers in this assay, from the lowest: compound 4; then compounds 2 and 3 (each within the scatter of the next). At a limit, above all of these: compound 1.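

In this assay, the change from anilino to amino depends on the core, with a 10-fold lower number from compound 2 to compound 4 (1.00 log units; beyond the scatter) when the methoxy group is present, a result not foreseen from the pair without it: the same change on two cores in this assay, an at least 1.2-fold lower number (0.09 log units; that floor lies within the scatter) from compound 1 to compound 3 and a 10-fold higher number (1.00 log units; beyond the scatter) from compound 4 to compound 2, at least 12-fold (1.09 log units) apart, beyond the scatter of two such steps

Methoxy in place of hydrogen on an aromatic carbon likewise gives an at least 16-fold lower number from compound 1 to compound 4 (1.22 log units; beyond the scatter) on the amino side, so among these compounds the low number appears only where methoxy and the hydrogen on the amide-type nitrogen occur together, in compound 4: the same change on two cores in this assay, a 1.3-fold higher number (0.12 log units; within the scatter) from compound 2 to compound 3 and an at least 16-fold higher number (1.22 log units; beyond the scatter) from compound 4 to compound 1, at least 12-fold (1.09 log units) apart, beyond the scatter of two such steps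

The reading for compound 1 is a limit, >= 5000 nM, so that step has a floor and no fixed size.

The compounds shown leave open whether an ethoxy or hydroxyl group in place of the methoxy keeps the low number of compound 4. They also leave open whether a methyl group in place of the hydrogen on the amide-type nitrogen keeps it.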